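A few compounds are considered here, and "the series" means these few. Any claim that something is new, unique, unknown or untested is made for them only; others in the source may bear on it.

Measured so far:
- compound 1 `Cn1ccc2cc(-c3cc4nccc(-c5ccc(F)cc5)n4n3)ccc21`: 2160 nM
- compound 2 `COc1cc(-c2ccnc3cc(-c4ccc(C(C)(C)C)cc4)nn23)cc(OC)c1OC`: > 10000 nM
- compound 3 `Cc1ccc(-c2cc3nccc(-c4ccc(F)cc4)n3n2)cc1`: > 10000 nM

These three compounds were tested in a functional assay on HCT-116 cells (Homo sapiens) for inhibition, read by CCK-8 assay, with a stated time of 48 h; on this read-out lower numbers stand for stronger inhibition and higher numbers for weaker inhibition. Compound 1 is the only one with a numerical result, and in this assay compound 1 gives 2160 nM. For compound 2 the assay reports only a limit, > 10000 nM, and not a number. Compound 3 likewise reaches only a limit, > 10000 nM. Compound 2 therefore stands at the weak end of what is shown, sharing the limit of > 10000 nM in this assay, at which 2 of the 3 values shown sit, with compound 3.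

Compound 4 `COc1cc(-c2ccnc3cc(-c4cn(C)c5ccccc45)nn23)cc(OC)c1OC` has not been measured. It differs from compound 2 in one place: 1-methyl-1H-indol-3-yl in place of 4-(tert-butyl)phenyl on an aromatic carbon. Among the measured compounds shown here, no measured pair of compounds shows the effect of this exact exchange, so its direction cannot be read from the data. The change in this assay is estimated as an at least 1.6-fold lower number from compound 2 to compound 4 (0.22 log units; that floor lies within the scatter), a gain that may not rise clearly beyond the scatter. Compound 4 is expected to give about 6000 nM, with a range from 1500 nM to 20000 nM, and a real chance that this assay again reports only a limit.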

Compound 4, half-maximal inhibitory concentration: 762 nM
The estimate for compound 4 lay 7.9-fold (0.90 log units) above the measured number, outside the stated range (below it).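

In this assay, exchanging 4-(tert-butyl)phenyl for 1-methyl-1H-indol-3-yl gives an at least 13-fold lower number from compound 2 to compound 4 (1.11 log units; beyond the scatter). This is the first pair shown that differs in one place, and it shows that the group on this aromatic carbon of the five-membered ring can, with the rest of the molecule unchanged, move a compound from a limit to a measured number. The true size of the step stays unknown because compound 2 has only a limit and not a number: the limit of > 10000 nM in this assay, at which 2 of the 4 values shown sit.

The compounds shown leave open whether the gain comes from the ring nitrogen of the entering group, from its five-membered ring, or simply from the loss of tert-butyl. They also do not show how an amine or a carboxylic acid on this same carbon would behave.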